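Amine variation on the shared core: compound 3 to compound 4

The source may hold more compounds than are shown below. What is called first, only, known or untested is meant among the compounds shown, and "the series" means these compounds.

The series shares one fused core. Compound 1 `CCC(COC)Nc1nc(C)nc2c1nnn2-c1c(C)cc(C)cc1C`, compound 2 `CCCC(C)Nc1nc(C)nc2c1nnn2-c1c(C)cc(C)cc1C` and compound 3 `Cc1nc(N2CCCC2)c2nnn(-c3ccc(C(C)C)cc3Br)c2n1` have been measured in an in vitro assay on 293-EBNA cells for binding affinity to corticotropin-releasing factor receptor 1 (Homo sapiens); on this read-out higher numbers stand for weaker inhibition and lower numbers for stronger inhibition. Compound 1 gives 59.4 nM, compound 2 gives 7.1 nM, and compound 3 gives 194 nM, the highest of the three numbers and beyond the scatter from both others, so compound 3 is the weakest binder measured so far. Within the data shown here, the only single-point step available, an 8.4-fold lower number from compound 1 to compound 2 (0.92 log units; beyond the scatter), exchanges the alkyl chain on the ring amine nitrogen and shows that this region of the molecule moves the read-out well beyond the scatter.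

Compound 4 `CCCCN(CC)c1nc(C)nc2c1nnn2-c1ccc(C(C)C)cc1Br` differs from compound 3 by butyl(ethyl)amino in place of pyrrolidin-1-yl on an aromatic carbon. Among the measured compounds shown here, no measured step covers the exchange of a cyclic amine for an open-chain dialkylamine, and compounds 1 and 2 carry a different aryl group, so the bearing of the step from compound 1 to compound 2 is indirect: it only establishes that altering the amine part of this core can shift affinity considerably. A lower number is therefore expected for compound 4, of moderate size, with a 5.5-fold lower number from compound 3 to compound 4 (0.74 log units; beyond the scatter) as the anticipated step. Compound 4 is estimated at 35 nM, with a range from 8 nM to 150 nM.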

Compound 4, inhibition constant: 7.5 nM
The estimate for compound 4 lay 4.7-fold (0.67 log units) above the measured number; the whole stated range lies above it.
By their numbers in this assay, from the lowest: compounds 2 and 4 (each within the scatter of the next); then compound 1; then compound 3.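

In this assay, butyl(ethyl)amino in place of pyrrolidin-1-yl on the aromatic carbon next to the ring nitrogen gives a 26-fold lower number from compound 3 to compound 4 (1.41 log units; beyond the scatter), a large change with the aryl group and the rest of the molecule held constant. The earlier step showed only that exchanging the alkyl chain on a ring amine nitrogen moves the read-out; this step shows that, on the aryl group of compound 3, the choice between a cyclic and an open-chain amine at this position matters strongly, and that here the open-chain amine gives the stronger inhibition. The entering group is both larger by heavy-atom count and free of a ring, with donor and acceptor counts unchanged, so the step does not separate ring opening from added size, and no available evidence bears on the reason for the change.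

As far as these compounds go, whether a larger cyclic amine such as piperidin-1-yl would behave like pyrrolidin-1-yl or like butyl(ethyl)amino remains open, as does the effect of a shorter open-chain amine such as diethylamino. Also open, from the compounds shown here alone, is whether the same exchange on the aryl group of compound 1 would give a step of similar size.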